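The source may report more compounds than this note shows. Statements on the series, on what has been measured and on what is new or still open speak of the compounds shown alone.

Working notes on the series. In a functional assay on DU-145 cells (Homo sapiens) for inhibition, read by trypan blue exclusion, with a stated time of 96 h (on this read-out lower numbers stand for stronger inhibition of growth and higher numbers for weaker inhibition of growth), compound 1 (`COc1ccc(/C=C(/Sc2ccc(C)cc2)C(=O)c2ccc(Br)cc2)cc1`) gives 50000 nM while compound 2 (`COc1ccc(/C=C(/SCc2ccc(Cl)cc2)C(=O)c2ccc(Br)cc2)cc1O`) gives 1000 nM and compound 3 (`O=C(/C(=C\c1ccc(Br)cc1)Sc1ccc(Br)cc1)c1ccc(Br)cc1`) sits at 1000 nM alongside it. Compound 2 is level with compound 3 within the scatter, the two sharing the lowest of the three numbers, and compound 1 lies beyond the scatter above them. Compound 4 (`O=C(/C(=C\c1cccc(Cl)c1Cl)SCc1ccc(Cl)cc1)c1ccc(Br)cc1`) carries 2,3-dichlorophenyl in place of 3-hydroxy-4-methoxyphenyl on a double-bonded chain carbon bound to a double-bonded chain carbon. Going by the values given here, no measured pair isolates this change. Compound 3 also has a halogen-bearing group on that chain carbon and gives 1000 nM in this series, so only a small move toward weaker inhibition is expected. The estimated step (a 1.5-fold higher number from compound 2 to compound 4 (0.18 log units; within the scatter)) stays within the scatter. Compound 4 is estimated at 1500 nM with an expected range from 300 nM to 8000 nM on this read-out.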

Compound 4, concentration for 50% growth inhibition: 10000 nM
Compound 4: the middle estimate sits 6.7-fold (0.82 log units) below what was measured; measured number above the stated range.
By their numbers in this assay, from the lowest: compounds 2 and 3 (each within the scatter of the next); then compound 4; then compound 1.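

In this assay, replacing 3-hydroxy-4-methoxyphenyl with 2,3-dichlorophenyl on this chain carbon gives a 10-fold higher number from compound 2 to compound 4 (1.00 log units; beyond the scatter) and so weakens inhibition of growth. The change removes the hydrogen-bond donor and acceptors of the leaving group while adding two chlorines, and this single pair cannot separate those differences. No evidence on hand accounts for the step.

On these data alone, it remains open whether the hydroxy or the methoxy group accounts for the difference. Also open, as far as these compounds go, is how a single chlorine, an amine or a carboxylic acid on this phenyl ring would compare with compound 2.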